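Sulfanyl in place of amino on the shared core

A few compounds are considered here, and "the series" means these few. Any claim that something is new, unique, unknown or untested is made for them only; others in the source may bear on it.

Values so far in an in vitro ADME assay on microsomes (Homo sapiens) for metabolic stability; a lower number here means that the compound disappears faster, a higher number that the compound lasts longer:
compound 1 `CCc1nc(N(CC2CC2)CC2CC2)c(CC)nc1-c1ccc(Cl)cc1Cl` at 0.133 h
compound 2 `CCCN(CCN(C)C)c1nc(CC)c(-c2ccc(Cl)cc2Cl)nc1CC` at 0.0833 h

Among the compounds with values here, compound 2 at 0.0833 h stands within the scatter of compound 1, the only other measured compound, so the two cannot be ranked. Compound 3 `CCc1nc(-c2ccc(Cl)cc2Cl)c(CC)nc1SC(C)CC` carries (sec-butyl)sulfanyl in place of (2-(dimethylamino)ethyl)(propyl)amino on an aromatic carbon, para to a 2,4-dichlorophenyl group ((sec-butyl)sulfanyl in place of (2-(dimethylamino)ethyl)(propyl)amino on an aromatic carbon).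

Within the data shown here, only one measured step bears on this change (a 1.6-fold lower number from compound 1 to compound 2 (0.20 log units; within the scatter)), and it exchanges one amino group for another. Among the measured compounds shown here, no measured compound carries a sulfanyl group, so that step is a weak guide. For the measured compounds named here, with the step (a 1.6-fold lower number from compound 1 to compound 2 (0.20 log units; within the scatter)) as the only evidence, no change beyond the scatter is expected in this assay in either direction, though with wide uncertainty. The estimated step (a 1.4-fold higher number from compound 2 to compound 3 (0.16 log units; within the scatter)) stays within the scatter. For compound 3 the estimate is 0.12 h with an expected range from 0.05 h to 0.3 h in this measurement.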

Compound 3, half-life: 0.283 h
Compound 3: the middle estimate sits 2.4-fold (0.37 log units) below what was measured, within the range that was stated.
By their numbers in this assay, from the lowest: compounds 2 and 1 (each within the scatter of the next); then compound 3.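

In this assay, within the data shown here, the (sec-butyl)sulfanyl group on this aromatic carbon, para to a 2,4-dichlorophenyl group, gives the first step at this position that lies beyond the scatter, a modest one: a 3.4-fold higher number from compound 2 to compound 3 (0.53 log units; beyond the scatter). The same direction appears against the other amino group, with a 2.1-fold higher number from compound 1 to compound 3 (0.33 log units; beyond the scatter), whereas the exchange of one amino group for another had stayed within the scatter, so among these three compounds only the change from an amino group to a sulfanyl group separates the numbers, though both steps are modest and each rests on a single pair. Nothing available explains why the sulfanyl compound lasts longer in this measurement.

On these data alone, the step changes the linking atom and the attached chain together, so it remains open whether the difference follows the sulfur or the sec-butyl group; a sec-butylamino or sec-butoxy group on the same carbon would separate the two. As far as these compounds go, whether the branch matters also remains open, and an n-butylsulfanyl or a longer straight-chain sulfanyl group would address that.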